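The compounds below may be only part of what the source reports. "The series", "measured", "known", "first", "only" and "open" are said of these compounds alone.

Measured compounds:
- compound 1, `COc1cc2c(cc1OC)C(=O)C(CC1CCN(C(=S)Nc3cccc([N+](=O)[O-])c3)CC1)C2`: "not determined" (no result reported)
- compound 2, `COc1cc2c(cc1OC)C(=O)C(CC1CCN(C(=S)Nc3ccccc3Cl)CC1)C2`: 300 mg/kg
- compound 3, `COc1cc2c(cc1OC)C(=O)C(CC1CCN(C(=S)Nc3cccc(Cl)c3)CC1)C2`: "not determined" (no result reported)

Compound 3 stands without a number in a functional assay on the whole organism (strain Swiss albino) with Mus musculus as the target, with a stated time of 4 h; on this read-out higher numbers stand for an effect only at larger amounts of compound and lower numbers for an effect already at smaller amounts; compound 1 is in the same position, so the only value among these compounds comes from compound 2, which in this assay gives 300 mg/kg. Compound 4, `CCCNC(=S)N1CCC(CC2Cc3cc(OC)c(OC)cc3C2=O)CC1`, arises from compound 3 through one change: propyl in place of 3-chlorophenyl on an amide-type nitrogen. For the measured compounds named here, no step between two measured compounds is available, so the size and direction of this change in this assay cannot be gauged from the data, and anything beyond the scatter would be a guess. Compound 4 is therefore expected to lie near 300 mg/kg, estimated between 100 mg/kg and 1000 mg/kg.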

Compound 4, minimum effective dose: 300 mg/kg
Compound 4: middle estimate and measured number agree at the digits printed; low and high end bracket the measured number.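

In this assay, for the compounds shown here, putting propyl in place of 2-chlorophenyl on the amide-type nitrogen gives no change at the digits printed from compound 2 to compound 4 (within the scatter), the first step that can be read at this position. This read-out therefore does not tell that aromatic ring from the shorter open chain, while steps involving compound 1 or compound 3 cannot be read. Nothing available here bears on why the two compounds match.

On these data alone, it remains open whether a longer chain, a cyclohexyl ring or a chain ending in an amine would also match. As far as these compounds go, the effect of moving the chlorine also stays open.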